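Methyl to 2,4-Difluorophenyl on the Sulfonyl Sulfur

The compounds below may be only part of what the source reports. "The series", "measured", "known", "first", "only" and "open" are said of these compounds alone.

Compound 1, `COc1ncc(-c2ccc3ncnc(Nc4cnn(CC(=O)O)c4)c3c2)cc1NS(=O)(=O)c1ccc(F)cc1F`: 5200 nM
Compound 2, `COc1ncc(-c2ccc3ncnc(Nc4ccc(OCCO)nc4)c3c2)cc1NS(C)(=O)=O`: 5080 nM

In a functional assay on A549 cells (Homo sapiens) for antiproliferative activity, read by sulforhodamine B assay, with a stated time of 72 h (a lower number here means a stronger inhibitor, a higher number a weaker inhibitor), compound 2 gives 5080 nM, a number that sits within the scatter of what compound 1 shows, so the two cannot be told apart. Compound 3, `COc1ncc(-c2ccc3ncnc(Nc4ccc(OCCO)nc4)c3c2)cc1NS(=O)(=O)c1ccc(F)cc1F`, differs from compound 2 in one place: 2,4-difluorophenyl in place of methyl on a sulfonyl sulfur. Among the measured compounds shown here, no measured pair isolates this change, and compound 1 carries the same group on a different amine side, so no step size can be drawn from the data. The step from compound 2 to compound 3 is expected to be a 1.3-fold lower number from compound 2 to compound 3 (0.10 log units; within the scatter), not beyond the scatter. Compound 3 is estimated at 4000 nM, with a range from 1500 nM to 12000 nM.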

Compound 3, half-maximal inhibitory concentration: 4120 nM
Estimate against measurement, compound 3: 1.0-fold (0.01 log units) below; the measured number falls inside the stated range.
By their numbers in this assay, from the lowest: compounds 3, 2 and 1 (each within the scatter of the next).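

In this assay putting 2,4-difluorophenyl in place of methyl on the sulfonyl sulfur gives a 1.2-fold lower number from compound 2 to compound 3 (0.09 log units; within the scatter) and so shows that this place carries eight heavy atoms and an aromatic ring without a step beyond the scatter. On the nitrogen on an aromatic ring, 6-(2-hydroxyethoxy)pyridin-3-yl in place of 1-(carboxymethyl)-1H-pyrazol-4-yl gives a 1.3-fold lower number from compound 1 to compound 3 (0.10 log units; within the scatter) and so does not separate the compounds either. Nothing given here accounts for these results. As far as these compounds go, what an amine or a longer alkyl chain on the sulfonyl sulfur would give remains open.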